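The source may hold more compounds than are shown below. What is called first, only, known or untested is meant among the compounds shown, and "the series" means these compounds.

Of the compounds shown here, two have been measured in a functional assay on NCI-H322M cells (Homo sapiens) for inhibition, read by sulforhodamine B assay, with a stated time of 48 h; a higher number here means a weaker inhibitor of growth, a lower number a stronger inhibitor of growth. Compound 1 `COc1ccc(-c2[nH]c3ccc(OC)cc3c2/C=C(\C#N)S(=O)(=O)c2ccccc2)cc1` gives 4300 nM in this assay. Compound 2 `CC(=O)/C(=C\c1c(-c2ccccc2)[nH]c2ccccc12)S(=O)(=O)c1ccccc1` gives 6100 nM in this assay, the higher of the two numbers, though its gap to compound 1 lies within the scatter, so the two compounds cannot be told apart on these numbers.

The next compound, compound 3 `N#C/C(=C\c1c(-c2ccccc2)[nH]c2ccccc12)S(=O)(=O)c1ccccc1`, has not yet been measured. It differs from compound 2 in one place: cyano in place of acetyl on a double-bonded chain carbon bound to a double-bonded chain carbon and a sulfonyl sulfur. Within the data shown here, no pair of measured compounds differing in exactly one place is available, so the size of this step has to be guessed. The step from compound 2 to compound 3 is expected to be small, a 1.4-fold lower number from compound 2 to compound 3 (0.13 log units; within the scatter), and possibly no larger than the scatter. Compound 3 is therefore expected to give about 4500 nM in this assay, somewhere between 1500 nM and 14000 nM.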

Compound 3, concentration for 50% growth inhibition: 9200 nM
Compound 3: middle estimate off by 2.0-fold (0.31 log units), on the low side, within the range that was stated.
By their numbers in this assay, from the lowest: compounds 1, 2 and 3 (each within the scatter of the next, the first and the last beyond it).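

In this assay, putting cyano in place of acetyl on a double-bonded chain carbon bound to a double-bonded chain carbon and a sulfonyl sulfur gives a 1.5-fold higher number from compound 2 to compound 3 (0.18 log units; within the scatter), so this swap does not separate the two compounds. Among these compounds, this pair gives the first direct reading at this position, and it shows measurable growth inhibition with either group there, so for this pair the acetyl carbonyl is not required for that inhibition. Nothing available explains why the two groups read alike.

Still open, as far as these compounds go, is whether a different group on the same carbon, such as a carboxylic acid or an amide, would move the number beyond the scatter. The effect of the methoxy groups on compound 1 cannot be read either, as it differs from compound 3 in more than one place.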